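Methyl for methoxy on the amide aryl ring

The source may hold more compounds than are shown below. What is called first, only, known or untested is meant among the compounds shown, and "the series" means these compounds.

Measured so far:
compound 1 `Cc1ccc(C(=O)Nc2cccc(-c3oc4cc(-c5ccc(F)cc5)ccc4c(=O)c3O)c2)cc1` — 6910 nM
compound 2 `COc1cccc(C(=O)Nc2cccc(-c3oc4cc(-c5ccc(F)cc5)ccc4c(=O)c3O)c2)c1` — 10800 nM

Two compounds share a core and differ only in the aryl group on the carbonyl carbon of the amide. In a functional assay on A549 cells (Homo sapiens) for antiproliferative activity, read by CCK-8 assay, with a stated time of 72 h (on this read-out higher numbers stand for weaker inhibition and lower numbers for stronger inhibition), compound 1 gives 6910 nM, and compound 2 gives 10800 nM. The single measured step, a 1.6-fold higher number from compound 1 to compound 2 (0.19 log units; within the scatter), lies within the scatter, so on the numbers shown compound 2 stands beside compound 1 rather than apart from it.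

Compound 3 `Cc1cccc(C(=O)Nc2cccc(-c3oc4cc(-c5ccc(F)cc5)ccc4c(=O)c3O)c2)c1` has not yet been measured. It differs from compound 2 by methyl in place of methoxy on an aromatic carbon, meta to a large group. For the measured compounds named here, the only step that bears on this is the one from compound 1 to compound 2, which swapped methyl for methoxy together with a change of position and stayed within the scatter. Nothing in the data points to a step beyond the scatter in this assay in either direction.

Compound 3 is therefore expected to give about 8500 nM in this assay, between 4000 nM and 18000 nM, a step of a 1.3-fold lower number from compound 2 to compound 3 (0.10 log units; within the scatter) that is expected to stay within the scatter.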

Compound 3, half-maximal inhibitory concentration: 16500 nM
Compound 3: middle estimate off by 1.9-fold (0.29 log units), on the low side; the measured number falls inside the stated range.
By their numbers in this assay, from the lowest: compounds 1, 2 and 3 (each within the scatter of the next, the first and the last beyond it).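

In this assay the exchange of 3-methoxyphenyl for 3-methylphenyl on the amide carbonyl, now seen alone with the position held fixed, gives a 1.5-fold higher number from compound 2 to compound 3 (0.18 log units; within the scatter) and so does not separate methoxy from methyl at this place. Moving the methyl group instead, from 4-methylphenyl to 3-methylphenyl, gives a 2.4-fold higher number from compound 1 to compound 3 (0.38 log units; beyond the scatter) and is the only step among these compounds to pass beyond the scatter, though it is modest and the group itself stays the same. The position of the methyl group on this ring therefore shows a small effect on the read-out, which the earlier pair could not show since it changed group and position together, and no available evidence accounts for this difference.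

The compounds shown leave open whether 4-methoxyphenyl would stand apart from 3-methoxyphenyl as 4-methylphenyl does from 3-methylphenyl, so the effect of position is known for methyl alone. They also leave open whether an amine, a carboxylic acid or a longer chain such as propyl on this aromatic ring would shift the number further in either direction.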